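The source may hold more compounds than are shown below. What is called first, only, known or untested is meant among the compounds shown, and "the series" means these compounds.

Series notes. Compound 1 `COCc1ccc(-c2ccc3nnc(C(N)=O)c(N[C@@H](C)c4ccn(C)n4)c3c2)cn1` is the reference point here. In an ADME assay on microsomes from liver (Homo sapiens) for metabolic stability, read by LC-MS, using NADPH, with a stated time of 30 min, tested at 1 uM (on this read-out higher numbers stand for fast clearance and lower numbers for slow clearance), compound 1 gives 14 mL.min-1.g-1, the lower of the two numbers recorded so far. Among the compounds with values here, its only measured neighbour is compound 2 `COCc1ccc(-c2ccc3nnc(C(N)=O)c(N[C@@H](C)c4nn(C)cc4C)c3c2)cn1`, which in this assay gives 31 mL.min-1.g-1; the step of a 2.2-fold higher number from compound 1 to compound 2 (0.35 log units; beyond the scatter) is the sole measured change, and it concerns methyl in place of hydrogen on an aromatic carbon, a change of a different kind from the one followed below.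

Compound 3 `C[C@H](Nc1c(C(N)=O)nnc2ccc(-c3ccc(OCCCN(C)C)nc3)cc12)c1ccn(C)n1` differs from compound 1 by 3-(dimethylamino)propoxy in place of methoxymethyl on an aromatic carbon, in words 3-(dimethylamino)propoxy in place of methoxymethyl on an aromatic carbon. Within the data shown here, no measured step bears on this exchange: the one step known, from compound 1 to compound 2, touches a different part of the structure and gives no guide to the size or direction of a change at this position. Among the measured compounds shown here, with no comparable step recorded, the expected change in this assay is stated only loosely, with a wide range. The value expected for compound 3 is 18 mL.min-1.g-1, with a range from 6 mL.min-1.g-1 to 50 mL.min-1.g-1, which corresponds to an estimated step of a 1.3-fold higher number from compound 1 to compound 3 (0.11 log units; within the scatter).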

Compound 3, intrinsic clearance in microsomes: 10 mL.min-1.g-1
For compound 3 the middle estimate is 1.8-fold (0.26 log units) above the measured one; the measured number falls inside the stated range.
By their numbers in this assay, from the lowest: compounds 3 and 1 (each within the scatter of the next); then compound 2.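

In this assay, placing 3-(dimethylamino)propoxy where methoxymethyl stood, on the aromatic carbon next to the ring nitrogen, gives a 1.4-fold lower number from compound 1 to compound 3 (0.15 log units; within the scatter), so compound 1 and compound 3 cannot be told apart on this read-out. Within the data shown here, this is the first reading at this position, as the earlier step concerned a different part of the structure; it shows that a chain of 7 heavy atoms carrying a dimethylamino end can stand here, in place of one of 3 heavy atoms, with intrinsic clearance remaining within the scatter of the reference. Nothing measured here accounts for this result.

The compounds shown leave open whether the same holds for a shorter chain such as 2-(dimethylamino)ethoxy, for a ring-bearing amine such as morpholine at the chain end, or for a carboxylic acid at that end. They also leave open whether the methyl on the aromatic carbon seen in compound 2 would have a similar effect on clearance when combined with the 3-(dimethylamino)propoxy chain.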